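The compounds below may be only part of what the source reports. "The series", "measured", "known", "first", "only" and "open" are said of these compounds alone.

Measured compounds in a functional assay on DU-145 cells (Homo sapiens) for cytotoxicity, read by MTT assay; on this read-out higher numbers stand for weaker inhibition and lower numbers for stronger inhibition:

- compound 1, `COc1ccc2cc([C@H](C)c3nnc(SCc4ccc(F)cc4)n3-c3ccc(F)cc3)ccc2c1`, gives 60200 nM
- compound 2, `COc1cccc(CSc2nnc([C@@H](C)c3ccc4cc(OC)ccc4c3)n2-c2ccc(F)cc2)c1`, gives 19200 nM
- compound 3, `COc1ccc2cc([C@H](C)c3nnc(SCc4ccccc4)n3-c3ccc(Cl)cc3)ccc2c1`, gives 35800 nM

All three share one core and differ only in the group on the benzyl carbon bound to sulfur and in the halogen on the pendant phenyl ring. On the numbers shown, compound 3 sits between compound 1 and compound 2, and its gap to each of them is within the usual scatter, so no real order among the three can be read from these values.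

Compound 4, `COc1ccc2cc([C@H](C)c3nnc(SCc4ccc(C)cc4)n3-c3ccc(Cl)cc3)ccc2c1`, differs from compound 3 only in one place: methyl in place of hydrogen on an aromatic carbon.

Within the data shown here, the one measured step that touches the benzyl ring, a 3.1-fold lower number from compound 1 to compound 2 (0.50 log units; beyond the scatter), concerns a different substituent in a different place, so it gives no direct guide. Among the measured compounds shown here, no other step bears on this change. The expectation is therefore a step of a 1.1-fold lower number from compound 3 to compound 4 (0.05 log units; within the scatter) in this assay, with no direction beyond the scatter. Compound 4 is estimated at 32000 nM, within a range from 12000 nM to 80000 nM.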

Compound 4, half-maximal inhibitory concentration: 18800 nM
The estimate for compound 4 lay 1.7-fold (0.23 log units) above the measured number; measured number inside the range.
By their numbers in this assay, from the lowest: compounds 4, 2, 3 and 1 (each within the scatter of the next, the first and the last beyond it).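

In this assay, methyl in place of hydrogen on an aromatic carbon of the benzyl ring gives a 1.9-fold lower number from compound 3 to compound 4 (0.28 log units; within the scatter). This is the first step shown for a change made directly on the unsubstituted benzyl ring, and it indicates that this added carbon, para to a large group, does not shift the read-out beyond the normal variation between repeat measurements. Nothing shown gives a measured explanation for this result.

Still open, as far as these compounds go, is whether a carboxylic acid, an amine or a longer chain such as butyl on the same ring carbon would produce a step beyond the scatter. A single step also cannot show whether methyl would behave in the same way with the fluorine-bearing pendant ring of compound 1 in place of the chlorine-bearing one of compound 3.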